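The source may hold more compounds than are shown below. What is called first, only, known or untested is meant among the compounds shown, and "the series" means these compounds.

In a functional assay on U2OS cells for antagonist activity at C-X-C chemokine receptor type 3 (Homo sapiens), read by beta-arrestin recruitment (a higher number here means a weaker inhibitor, a lower number a stronger inhibitor), compound 1 `CCOc1ncc(-c2nc(C(F)(F)F)sc2N2CCN(C(=O)Cn3nccc3C)[C@H](C)C2)cn1` gives 162 nM, and compound 2 `CCOc1ncc(-c2nc(C(F)(F)F)sc2N2CCN(C(=O)Cn3nc(C)nc3C)[C@H](C)C2)cn1` gives 173 nM; the step of a 1.1-fold higher number from compound 1 to compound 2 (0.03 log units; within the scatter) lies within the scatter, so neither can be called the stronger. Compound 3 `Cc1ncc(-c2nc(C(F)(F)F)sc2N2CCN(C(=O)Cn3nc(C)nc3C)[C@H](C)C2)cn1` carries methyl in place of ethoxy on an aromatic carbon. Going by the values given here, no measured step touches that position: the single step available changes a different part of the shared core and left the number essentially unmoved, so it gives no direct guidance. Compound 3 is therefore expected to show a modest rise, a 1.8-fold higher number from compound 2 to compound 3 (0.27 log units; within the scatter), with wide uncertainty. Compound 3 is estimated at 320 nM, in a range from 110 nM to 950 nM.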

Compound 3, half-maximal inhibitory concentration: 578 nM
Estimate against measurement, compound 3: 1.8-fold (0.26 log units) below; low and high end bracket the measured number.
By their numbers in this assay, from the lowest: compounds 1 and 2 (each within the scatter of the next); then compound 3.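

In this assay the change from 2-ethoxypyrimidin-5-yl to 2-methylpyrimidin-5-yl gives a 3.3-fold higher number from compound 2 to compound 3 (0.52 log units; beyond the scatter), so this position, unlike the site changed between compound 1 and compound 2, moves the number beyond the scatter. Here ethoxy gives the stronger inhibitor of the pair, and the change removes one oxygen and a net two carbons. Nothing shown offers a reason for this rise.

On these data alone, whether the oxygen or the chain length matters remains open, and a methoxy or propoxy group would help separate them. Also open, as far as these compounds go, is whether the same step would hold with the 5-methyl-1H-pyrazol-1-yl group of compound 1.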